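The compounds below may be only part of what the source reports. "The series", "measured", "known", "first", "only" and "open" are said of these compounds alone.

Three compounds share one core and differ only in the group carried on an amine nitrogen in a ring. Compound 1 `CCCCNc1nc(N)nc2c1CN(Cc1c(Cl)cccc1Cl)CC2` gives 0.14 uM in an assay on HEK293 cells for agonist activity at Toll-like receptor 8 (Homo sapiens), read by a luciferase reporter, with a stated time of 6 h; a higher number here means that more compound is needed for the effect, a lower number that less compound is needed; compound 2 `CCCCNc1nc(N)nc2c1CN(Cc1cc(F)cc(F)c1)CC2` gives 0.23 uM; compound 3 `CCCCNc1nc(N)nc2c1CN(Cc1ccco1)CC2` gives 0.08 uM. Compound 3 has the lowest number of the three: the gap to compound 1 is within the scatter, while a 2.9-fold lower number from compound 2 to compound 3 (0.46 log units; beyond the scatter) is beyond it. Compound 4 `CCCCNc1nc(N)nc2c1CN(C(=O)c1cc(C)on1)CC2` alters this same position: (5-methyl-1,2-oxazol-3-yl)carbonyl in place of (furan-2-yl)methyl on an amine nitrogen in a ring. The measured steps, a 1.6-fold higher number from compound 1 to compound 2 (0.22 log units; within the scatter) and a 1.8-fold lower number from compound 1 to compound 3 (0.24 log units; within the scatter), swap one aromatic ring for another on a saturated chain carbon, and both stay small. Within the data shown here, none of them places a carbonyl on the amine nitrogen in a ring, so no measured step bears directly on the move to compound 4. With the three measured numbers clustered closely and the new change untested, the expectation for compound 4 is a somewhat higher number, a 6.3-fold higher number from compound 3 to compound 4 (0.80 log units; beyond the scatter), carrying wide uncertainty. Compound 4 is therefore estimated at 0.5 uM, within a range from 0.1 uM to 3 uM.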

Compound 4, minimum effective concentration: 0.4 uM
The estimate for compound 4 lay 1.3-fold (0.10 log units) above the measured number, within the range that was stated.
By their numbers in this assay, from the lowest: compounds 3, 1, 2 and 4 (each within the scatter of the next, the first and the last beyond it).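

Earlier steps at this position only swapped one aromatic ring for another on a saturated chain carbon, whereas compound 4 puts a carbonyl directly on the amine nitrogen in a ring and brings in a ring with 2 hetero atoms. In this assay this change gives a 5.0-fold higher number from compound 3 to compound 4 (0.70 log units; beyond the scatter) and is a modest step, so the position accepts a carbonyl-linked group with compound 4 still active at 0.4 uM in this test. Nothing measured here gives a reason for the shift.

On these data alone, the carbonyl and the new ring change together in this single step, so how much of the shift belongs to each stays open. A (furan-2-yl)carbonyl group or a (5-methyl-1,2-oxazol-3-yl)methyl group on the same nitrogen would separate the two.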